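This account rests on a few compounds, and the source may have more. Where it says the series, first, only, none or still open, it means among the compounds named here.

Compound 2 `O=C(/C=C/c1cc2ccccc2[nH]c1=O)c1ccc(O)cc1` gives, in an ADME assay on HOP-92 cells (Homo sapiens) for cytotoxicity, read by sulforhodamine B assay, with a stated time of 24 h (a lower number here means that less compound is tolerated, a higher number that more compound is tolerated), only an assay limit, > 100000 nM. Compound 1 `COc1ccc(C(=O)/C=C/c2cc3ccccc3[nH]c2=O)cc1` gives 80900 nM in this assay. For the measured compounds named here, the single measured step, an at least 1.2-fold higher number from compound 1 to compound 2 (0.09 log units; that floor lies within the scatter), ends at a limit, (the limit of > 100000 nM in this assay, at which 1 of the 2 values shown sits), so its true size is not known. Compound 3 `O=C(/C=C/c1cc2ccccc2[nH]c1=O)c1ccc(Cl)cc1` differs from compound 2 by chloro in place of hydroxy on an aromatic carbon. Going by the values given here, no measured step covers this particular change, and the one step available lies within the scatter, so the expected step of an at least 1.1-fold lower number from compound 2 to compound 3 (0.04 log units; that floor lies within the scatter) is small. Compound 3 is therefore expected to give 90000 nM, with a range from 40000 nM to 200000 nM.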

Compound 3, concentration lethal to 50% of the cells: > 100000 nM
Compound 3: no number, only a limit (the forecaster's own chance of this, stated with the estimate: 55%); middle value at least 1.1-fold (0.04 log units) away from the limit.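

Compound 3 gives only a limit in this assay, not a number, and so the step from compound 2 cannot be read. For the compounds shown here, the one readable comparison is an at least 1.2-fold higher number from compound 1 to compound 3 (0.09 log units; that floor lies within the scatter), with chloro in place of methoxy. Chloro, with 0 hydrogen-bond donors and 0 hydrogen-bond acceptors, thus leaves the compound at the same limit as hydroxy, which has 1 of each: the limit of > 100000 nM in this assay, at which 2 of the 3 values shown sit.

As far as these compounds go, how compound 2 and compound 3 truly rank remains open. So does whether an amine or a carboxylic acid at this place would give a readable number.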